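This account rests on a few compounds, and the source may have more. Where it says the series, first, only, none or still open, it means among the compounds named here.

Measured compounds:
Compound 1 `CCCN(Cc1ccc(OCCn2c(=O)ccn(C)c2=O)c(OC)c1)C(CC(=O)O)c1ccc(Cl)cc1`: in an ADME assay on liver (Homo sapiens) for metabolic stability, read by LC-MS, using microsomes and NADPH (on this read-out lower numbers stand for a less stable compound and higher numbers for a more stable compound), compound 1 gives 61%.
Compound 2 `CCCN(Cc1ccc(OCCn2c(=O)ccn(C)c2=O)c(OC)c1)C(CC(=O)O)c1ccc2c(c1)CCO2`: in this assay compound 2 gives 83%.
Compound 3 `COc1cc(CN(CC(C)C)C(CC(=O)O)c2ccc3c(c2)CCO3)ccc1OCCN1C(=O)CCC1=O`: in this assay compound 3 gives 92%.

Compound 2 and compound 1 differ in one place, (a group of 7 heavy atoms (6 carbon, 1 chlorine; one six-membered aromatic ring of carbon only) in place of a group of 9 heavy atoms (8 carbon, 1 oxygen; one five-membered non-aromatic ring with 1 hetero atom, one six-membered aromatic ring of carbon only), on a saturated chain carbon bound to an amine nitrogen and a saturated chain carbon), and this change made a step of a number 22 percentage points lower from compound 2 to compound 1 (beyond the scatter). The difference between the core of compound 3 and the core of compound 2 is not broken down here. Compound 3 and compound 2 lie within the scatter of each other in this assay; compound 3 stands beyond the scatter only against compound 1.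

Compound 4 `COc1cc(CN(CC(C)C)C(CC(=O)O)c2ccc(Cl)cc2)ccc1OCCN1C(=O)CCC1=O`, not yet measured, carries the same change on the core of compound 3: a group of 7 heavy atoms (6 carbon, 1 chlorine; one six-membered aromatic ring of carbon only) in place of a group of 9 heavy atoms (8 carbon, 1 oxygen; one five-membered non-aromatic ring with 1 hetero atom, one six-membered aromatic ring of carbon only), on a saturated chain carbon bound to an amine nitrogen and a saturated chain carbon. The place is worded the same in both pairs, so the change is taken as the same. Compound 4 is expected to show a number 22 percentage points lower from compound 3 to compound 4 (beyond the scatter), because the same change earlier gave a number 22 percentage points lower from compound 2 to compound 1 (beyond the scatter). For compound 4 the estimate is 70%, expected to lie between 55% and 84%.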

Compound 4, percent of the compound remaining in the Homo sapiens assay: 80%
Estimate against measurement, compound 4: 10 percentage points below, and the stated range covers the measured number.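

In the Homo sapiens assay, 4-chlorophenyl entering on a saturated chain carbon bound to an amine nitrogen and a saturated chain carbon gave a number 12 percentage points lower from compound 3 to compound 4 (beyond the scatter), the same direction as on the earlier core, leaving compound 4 at 80%. The two steps agree in direction and their sizes cannot be told apart, so on these two cores the change carries over: the same change on two cores in the Homo sapiens assay, a number 22 percentage points lower (beyond the scatter) from compound 2 to compound 1 and a number 12 percentage points lower (beyond the scatter) from compound 3 to compound 4, 10 percentage points apart, within the scatter of two such steps. This rests on two pairs only and does not show that the step would hold its size on any other core. In a physicochemical assay for solubility, at pH 1.1 (a lower number here means a less soluble compound, a higher number a more soluble compound), compound 3 gives 3000000 nM and compound 4 gives 3000000 nM.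

Still open, from the compounds shown here alone, is how a pyridine ring or a 4-fluorophenyl group would compare in the same place. Also open, going by these compounds, is whether the step survives on a core with an amide in place of the carboxylic acid.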